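The source may hold more compounds than are shown below. What is called first, only, known or untested is meant among the compounds shown, and "the series" means these compounds.

Measured compounds:
Compound 1, `O=C1CCCC2=C1C(c1ccc(F)cc1Cl)N=C(c1cnccn1)N2`: 777000 nM
Compound 2, `O=C1CCCC2=C1C(c1ccccc1Cl)N=C(c1cnccn1)N2`: 1470000 nM
Compound 3, `O=C1CCCC2=C1C(c1ccc(F)cc1)N=C(c1cccnc1)N2`: 281000 nM

All three were tested in an ADME assay on HepG2 2.2.15 cells (Homo sapiens) for cytotoxicity; a higher number here means a weaker inhibitor, a lower number a stronger inhibitor. Compound 1 and compound 2 share one core and differ in a single spot: hydrogen in place of fluoro on an aromatic carbon. That change produced a 1.9-fold higher number from compound 1 to compound 2 (0.28 log units; within the scatter), so the two values cannot be told apart with confidence.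

Compound 3 carries a different core, and the difference between the two cores is not broken down here; its number is the lowest of the three, separated from compound 1 and compound 2 by steps that exceed the usual scatter.

Compound 4, `O=C1CCCC2=C1C(c1ccccc1)N=C(c1cccnc1)N2`, has not yet been measured. It relates to compound 3 in the following way: hydrogen in place of fluoro on an aromatic carbon. Among the compounds with values here, this is the same kind of change as the one from compound 1 to compound 2, although the surroundings are not identical: in compound 1 the fluoro sits meta to a chloro group and para to a large group, while in compound 3 it sits only para to a large group.

Because the earlier step gave a 1.9-fold higher number from compound 1 to compound 2 (0.28 log units; within the scatter), compound 4 is expected to land close to compound 3, with a step of about a 1.5-fold higher number from compound 3 to compound 4 (0.17 log units; within the scatter) in this assay. The estimate for compound 4 is therefore 420000 nM, within a range of 150000 nM to 1100000 nM.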

Compound 4, half-maximal inhibitory concentration: 369000 nM
For compound 4 the middle estimate is 1.1-fold (0.06 log units) above the measured one, within the range that was stated.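

In this assay, putting hydrogen in place of the fluoro, which turns the 4-fluorophenyl group into phenyl, gave a 1.3-fold higher number from compound 3 to compound 4 (0.12 log units; within the scatter), so this step cannot be told apart from the ordinary spread of repeated measurements. Set beside the earlier step, the new one agrees with it, and the change reads the same on both cores: the same change on two cores in this assay, a 1.9-fold higher number (0.28 log units; within the scatter) from compound 1 to compound 2 and a 1.3-fold higher number (0.12 log units; within the scatter) from compound 3 to compound 4, 1.4-fold (0.16 log units) apart, within the scatter of two such steps. This shows that, on these two cores, swapping this fluoro for hydrogen gives no step large enough to be sure of, but it does not show that the fluoro has no effect at all, that the same would hold on a third core, or why the two steps agree.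

The compounds shown leave open whether a different group on the aromatic carbon para to a large group, such as a methoxy group, an amine or a carboxylic acid, would move the number beyond the scatter. They also leave open which of the several differences between the core of compound 1 and the core of compound 3 accounts for the gap between their numbers.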